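The source may hold more compounds than are shown below. What is called first, only, known or untested is meant among the compounds shown, and "the series" means these compounds.

Measured in a functional assay on MDA-MB-231 cells (Homo sapiens), read by microscopy and transwell migration, with a stated time of 24 h; on this read-out higher numbers stand for weaker inhibition and lower numbers for stronger inhibition:
- compound 1 `COc1ccc(C(=O)Nc2nc(-c3cc(OC)c(OC)c(OC)c3)cs2)cc1OC`: > 25000 nM (a limit of the assay)
- compound 2 `COc1cc(-c2csc(NC(=O)c3cccc(OC)c3OC)n2)cc(OC)c1OC`: 15000 nM
- compound 3 `COc1ccccc1C(=O)Nc1nc(-c2cc(OC)c(OC)c(OC)c2)cs1`: 8500 nM

Among the compounds with exact numbers, compound 2 stands close to compound 3, as a 1.8-fold lower number from compound 2 to compound 3 (0.25 log units; within the scatter) shows. Compound 4 `COc1cc(-c2csc(N(C)C(=O)c3cccc(OC)c3OC)n2)cc(OC)c1OC` differs from compound 2 by methyl in place of hydrogen on an amide-type nitrogen. Among the measured compounds shown here, no measured step touches that nitrogen. All of them change the group on the carbonyl carbon, including an at least 1.6-fold lower number from compound 1 to compound 2 (0.22 log units; that floor lies within the scatter) and an at least 2.9-fold lower number from compound 1 to compound 3 (0.46 log units; beyond the scatter). They hint at how large steps in this small set can be, but give no direction for the new change. No step beyond the scatter is therefore expected in this assay, though with wide uncertainty. The expected change is a 1.5-fold lower number from compound 2 to compound 4 (0.18 log units; within the scatter). For compound 4 the estimated value is 10000 nM, with an expected range of 1500 nM to 25000 nM.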

Compound 4, half-maximal inhibitory concentration: 108 nM
Beside the measured number, compound 4's estimate is 93-fold (1.97 log units) above it; measured number outside the range, below it.
By their numbers in this assay, from the lowest: compound 4; then compounds 3 and 2 (each within the scatter of the next). At a limit, above all of these: compound 1.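

In this assay, methyl in place of hydrogen on the amide-type nitrogen gives a 140-fold lower number from compound 2 to compound 4 (2.14 log units; beyond the scatter), so a lower number here means much stronger inhibition. The earlier compounds shown here varied only the group on the carbonyl carbon, and this nitrogen now proves to be a position where a single added methyl matters greatly. Nothing shown here explains why this change has so large an effect. Going by these compounds, it remains open whether an ethyl group or a longer chain on this nitrogen would do the same. On these data alone, it also remains open whether methyl on this nitrogen would act alike with the other carbonyl groups, those of compound 1 and compound 3.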